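The compounds below may be only part of what the source reports. "The series", "measured", "known", "first", "only" and "open" are said of these compounds alone.

Among the compounds with values here, compound 2 `CN(C)CCCCn1c(-c2c(N)n(C)c3nc(C#N)c(C#N)nc23)nc2ccccc21` holds the only actual number so far: in a functional assay on HL-60 cells (Homo sapiens) for antiproliferative activity, read by MTT assay, with a stated time of 48 h (on this read-out higher numbers stand for weaker inhibition and lower numbers for stronger inhibition), compound 2 gives 2270 nM. Compound 1 `Cn1c(N)c(-c2nc3ccccc3[nH]2)c2nc(C#N)c(C#N)nc21` reads > 50000 nM in this assay, and that value is a limit, not a number. Within the data shown here, the one measured step, an at least 22-fold lower number from compound 1 to compound 2 (1.34 log units; beyond the scatter), puts 4-(dimethylamino)butyl in place of hydrogen on an aromatic nitrogen, and its size is anchored at one end by the limit of > 50000 nM in this assay, at which 1 of the 2 values shown sits.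

Compound 3 `CCN(CC)CCCCn1c(-c2c(N)n(C)c3nc(C#N)c(C#N)nc23)nc2ccccc21` differs from compound 2 only at the amine end of that chain: diethylamino in place of dimethylamino on a saturated chain carbon, four bonds along the chain from an aromatic nitrogen. Among the measured compounds shown here, the measured step bears on this only indirectly, as it adds the whole chain, and no measured pair exchanges dimethylamino for another group. The large size of that step therefore does not carry over to this smaller change. With compound 2 at 2270 nM as the anchor, no shift beyond the scatter is expected in this assay, and no firm direction can be assigned. The estimated step is a 1.1-fold lower number from compound 2 to compound 3 (0.03 log units; within the scatter). For compound 3 the expected value is 2100 nM, with an estimated range of 800 nM to 5500 nM.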

Compound 3, half-maximal inhibitory concentration: 2860 nM
The estimate for compound 3 lay 1.4-fold (0.13 log units) below the measured number; the range from low to high includes it.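

In this assay, a 1.3-fold higher number from compound 2 to compound 3 (0.10 log units; within the scatter), for diethylamino in place of dimethylamino on a saturated chain carbon, four bonds along the chain from an aromatic nitrogen; at this position, the larger of these amine ends therefore gives no change that can be told from the scatter. The large drop seen with the chain is no longer tied to a single amine end, since an at least 17-fold lower number from compound 1 to compound 3 (1.24 log units; beyond the scatter), here with the chain that ends in diethylamino. The value of compound 1 is a limit and not a number, so the true size of the steps from it stays unfixed: the limit of > 50000 nM in this assay, at which 1 of the 3 values shown sits.

As far as these compounds go, it remains open whether the amine is needed at all, as a plain butyl chain or a chain ending in a hydroxyl group would show, and whether a ring amine such as pyrrolidine, piperidine or morpholine at the chain end would hold the same level. Also open, from the compounds shown here alone, is how the read-out responds to chain length, from 2-(dimethylamino)ethyl and 3-(dimethylamino)propyl to a longer chain.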